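Hydroxy on the 2-phenylethenyl group: outlook for compound 3

The source may report more compounds than this note shows. Statements on the series, on what has been measured and on what is new or still open speak of the compounds shown alone.

compound 1 `O=C(/C=C\c1ccccc1)N1N=C(c2ccncc2)OC1c1c[nH]c2ccccc12`: > 30 ug/mL
compound 2 `O=C(/C=C\c1ccccc1O)N1N=C(c2ccncc2)OC1c1c[nH]c2ccccc12`: 26.8 ug/mL

In an ADME assay on HeLa cells (Homo sapiens) for cytotoxicity, read by MTT assay, with a stated time of 72 h (a higher number here means a weaker inhibitor of growth, a lower number a stronger inhibitor of growth), compound 1 gives > 30 ug/mL, which is a limit of the assay and not a number. Compound 1 thus stands at the limit of > 30 ug/mL in this assay, at which 1 of the 2 values shown sits. Compound 2 gives 26.8 ug/mL. Going by the values given here, the single measured step, an at least 1.1-fold lower number from compound 1 to compound 2 (0.04 log units; that floor lies within the scatter), sets only a floor that lies within the scatter.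

Compound 3 `O=C(/C=C\c1cccc(O)c1)N1N=C(c2ccncc2)OC1c1c[nH]c2ccccc12` differs from compound 1 by hydroxy in place of hydrogen on an aromatic carbon. Among the compounds with values here, only the step from compound 1 to compound 2 bears on this change, and it showed nothing beyond the scatter, so in this assay no step beyond the scatter is expected. Compound 3 is expected near 30 ug/mL, between 15 ug/mL and 60 ug/mL, an expected step of a number no higher from compound 1 to compound 3 (the limit leaves the size open).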

Compound 3, concentration for 50% growth inhibition: > 30 ug/mL
Compound 3 gave a limit, no number; the forecaster's own chance of this, stated with the estimate: 50%; the middle value lies on the limit itself.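

In this assay compound 3 gives a limit and not a number, as compound 1 does: the limit of > 30 ug/mL in this assay, at which 2 of the 3 values shown sit. The step between these two compounds cannot be read, so hydroxy at this place shows no measurable change from hydrogen. Between the two hydroxy placements there is an at least 1.1-fold higher number from compound 2 to compound 3 (0.04 log units; that floor lies within the scatter), so the 2-(3-hydroxyphenyl)ethenyl compound is not separated from its 2-hydroxyphenyl counterpart.

From the compounds shown here alone, it remains open whether an amine or a carboxylic acid on this aromatic carbon would give a step beyond the scatter. Going by these compounds, it also remains open whether any replacement on this ring would move the series clearly away from the limit.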